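The compounds below may be only part of what the source reports. "The series", "measured", "known", "first", "only" and "open" are said of these compounds alone.

Compound 1 `S=C(Nc1ccccc1)OCCc1ccccn1` stands at a limit in an ADME assay on MT4 cells (Homo sapiens) for cytotoxicity, read by MTT assay (a higher number here means that more compound is tolerated, a lower number that less compound is tolerated), giving > 100000 nM rather than a number. Its two measured neighbours differ on the aromatic ring of the aniline part: compound 2 `O=[N+]([O-])c1cccc(NC(=S)OCCc2ccccn2)c1` gives 100000 nM, and compound 3 `COc1ccc(NC(=S)OCCc2ccccn2)cc1` gives 48000 nM. Going by these compounds, the steps are a number no higher from compound 1 to compound 2 (the limit leaves the size open) and an at least 2.0-fold lower number from compound 1 to compound 3 (0.31 log units; beyond the scatter); their sizes stay open because compound 1 sits at the limit (the limit of > 100000 nM in this assay, at which 1 of the 3 values shown sits). Compound 4 `S=C(Nc1ccccc1)OCCc1cccs1` differs elsewhere, (thiophen-2-yl in place of pyridin-2-yl on a saturated chain carbon, two bonds along the chain from an oxygen on an unsaturated carbon). Neither measured step touches that chain position, so they say little about it. Compound 4 is expected to remain about as well tolerated, with an estimated 100000 nM in this assay, between 40000 nM and 250000 nM. That expectation means the step of a number no higher from compound 1 to compound 4 (the limit leaves the size open).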

Compound 4, half-maximal cytotoxic concentration: > 100000 nM
Compound 4: no number, only a limit; the forecaster's own chance of this, stated with the estimate: 50%; the middle value sits exactly at the limit.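

No step can be read between compound 1 and compound 4, because each gives only a limit and no number: the limit of > 100000 nM in this assay, at which 2 of the 4 values shown sit.

The compounds shown leave open whether thiophen-2-yl and pyridin-2-yl differ at all in this assay.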